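Methoxy for hydrogen on the phenyl of compound 1

This account rests on a few compounds, and the source may have more. Where it says the series, first, only, none or still open, it means among the compounds named here.

Measured so far:
compound 1 `Cc1nnc(SCC(=O)N/N=c2/scc(-c3ccccc3)n2-c2ccccc2)s1`, 72.5%
compound 2 `Cc1ccc(-c2cs/c(=N/NC(=O)CSc3nnnn3C)n2-c2ccccc2)cc1`, 68.8%

In a functional assay on C6 cells (Rattus norvegicus) for cytotoxicity, read by MTT assay, with a stated time of 24 h, tested at 12 ug/mL (on this read-out lower numbers stand for a stronger effect and higher numbers for a weaker effect at the one concentration tested), compound 1 gives 72.5%. Going by the values given here, compound 2 gives 68.8% in this assay, and the two numbers lie within the scatter of each other, so compound 1 cannot be set apart from compound 2 on this read-out; nothing more is said of the pair, since no step between the two is computed.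

Compound 3 `COc1ccc(-c2cs/c(=N/NC(=O)CSc3nnc(C)s3)n2-c2ccccc2)cc1` has not yet been measured. It differs from compound 1 as follows: methoxy in place of hydrogen on an aromatic carbon. Among the compounds with values here, no measured pair shows the effect of such a change in this assay, so the direction is open; the expectation is that the step from compound 1 to compound 3 stays within the scatter, with no lean either way.

Taking compound 1 as the anchor at 72.5%, compound 3 is expected to land at 70%, within 55% to 85%. That expected step is a number 2.5 percentage points lower from compound 1 to compound 3 (within the scatter), nothing beyond the scatter.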

Compound 3, a percentage reported as activity, at one concentration (the size of the read-out at that concentration, not a potency): 53.6%
The estimate for compound 3 lay 16.4 percentage points above the measured number; the whole stated range lies above it.
By their numbers in this assay, from the lowest: compound 3; then compounds 2 and 1 (each within the scatter of the next).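

In this assay, the phenyl of compound 1 proves sensitive to substitution: phenyl to 4-methoxyphenyl, with methoxy in place of hydrogen on an aromatic carbon, para to a large group, gives a number 18.9 percentage points lower from compound 1 to compound 3 (beyond the scatter). Going by these compounds alone, the earlier compounds held no step in one place, so this is the first sign that the series responds to a change at this position, and here the change goes towards a stronger effect at the one concentration tested. No measurement on these compounds gives a reason for the step.

One substituent cannot show whether the gain is particular to methoxy or would also come with a hydroxy group, an amine, a carboxylic acid or a longer alkoxy chain at the same place. Also open, as far as these compounds go, is whether methoxy elsewhere on that ring would give a step of similar size.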